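The source may hold more compounds than are shown below. What is called first, only, known or untested is meant among the compounds shown, and "the series" means these compounds.

For the measured compounds named here, compound 1 `NCCNc1cc(N2CCN(c3cccc(Cl)c3)CC2)nc2ccccc12` gives 6400 nM in an ADME assay on HEp-2 cells (Homo sapiens) for cytotoxicity, read by CCK-8 assay, with a stated time of 6 days; a lower number here means that less compound is tolerated, a higher number that more compound is tolerated; it is the only number so far. Compound 2 `CC(=O)N1CCN(c2cc(NCCN)c3ccccc3n2)CC1` reaches only the limit > 100000 nM in this assay, a limit and not a number, as noted in the limit of > 100000 nM in this assay, at which 1 of the 2 values shown sits. Going by the values given here, the one measured step, an at least 15-fold higher number from compound 1 to compound 2 (1.19 log units; beyond the scatter), is large, but it exchanges the whole aryl group on the ring amine nitrogen for acetyl.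

Compound 3 `NCCNc1cc(N2CCN(c3ccc(Cl)cc3)CC2)nc2ccccc12` differs from compound 1 by 4-chlorophenyl in place of 3-chlorophenyl on an amine nitrogen in a ring, on an amine nitrogen in a ring of a six-membered non-aromatic ring with two nitrogen. Among the compounds with values here, no measured step covers a change of this kind; the aryl group stays and only its chlorine moves. The step of no change at the digits printed from compound 1 to compound 3 (within the scatter) is therefore expected to stay within the scatter, in no firm direction. Compound 3 is estimated at 6400 nM, with a range from 2500 nM to 16000 nM.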

Compound 3, half-maximal cytotoxic concentration: 6600 nM
Beside the measured number, compound 3's estimate is 1.0-fold (0.01 log units) below it; the range from low to high includes it.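

Exchanging 3-chlorophenyl for 4-chlorophenyl on the amine nitrogen in the ring gives a 1.0-fold higher number from compound 1 to compound 3 (0.01 log units; within the scatter), so this assay does not separate these two chlorophenyl groups. The large gap to the acetyl compound now holds for both of them and not for one aryl group alone, with an at least 15-fold lower number from compound 2 to compound 3 (1.18 log units; beyond the scatter). That gap has an open upper end, as compound 2 gives a limit and not a number: the limit of > 100000 nM in this assay, at which 1 of the 3 values shown sits.

On these data alone, whether the chlorine contributes at all remains open, and an unsubstituted phenyl on the same nitrogen would address this directly. Also open, as far as these compounds go, is where a small group without a carbonyl, such as methyl, would fall relative to the chlorophenyl compounds and the acetyl compound, and how far a longer chain in place of the aminoethyl group would move the number.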